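This account rests on a few compounds, and the source may have more. Where it says the series, first, only, none or still open, it means among the compounds named here.

Compound 1, `Cn1c(=O)[nH]c2c(cnn2-c2cc(Cl)ccc2Cl)c1=N`: 1%
Compound 2, `Cn1c(=O)[nH]c2c(cnn2-c2cc(Cl)cc(Cl)c2)c1=N`: 29%
Compound 3, `Cn1c(=O)[nH]c2c(cnn2-c2cccc(Br)c2)c1=N`: 40%

Three compounds share a core and differ only in the aryl group attached to it. All three were measured in an assay on membranes from brain for binding affinity to adenosine receptor A1 (Rattus norvegicus), read by radioligand binding, tested at 20 uM; on this read-out higher numbers stand for more inhibition at the one concentration tested (going by the name of the read-out) and lower numbers for less inhibition. On that read-out compound 3 stands highest of the three numbers. Its nearest neighbour is compound 2, whose number lies lower by a margin beyond the usual scatter, and the furthest is compound 1, whose number lies lower still, again beyond the scatter. No two of these measured compounds differ in a single place, so none of the gaps between them can be read as the effect of one change.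

Compound 4, `Cn1c(=O)[nH]c2c(cnn2-c2cccc(Cl)c2)c1=N`, has not yet been measured. It differs from compound 3 in one place: chloro in place of bromo on an aromatic carbon. Among the compounds with values here, nothing among the measured compounds shows what such an exchange of one halogen for another at this position does. The expected step from compound 3 to compound 4 is therefore small, a number 8 percentage points lower from compound 3 to compound 4 (within the scatter), and may well fall within the scatter, with a slight lean downward. Compound 4 is estimated at 32%, with a range from 15% to 50%.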

Compound 4, a percentage reported as inhibition, at one concentration (the size of the read-out at that concentration, not a potency): 53%
Beside the measured number, compound 4's estimate is 21 percentage points below it, and the stated range ends below it.
By their numbers in this assay, from the lowest: compound 1; then compound 2; then compound 3; then compound 4.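

In this assay, the exchange of one halogen for another on this aromatic carbon, meta to a large group, proves to matter: chloro in place of bromo gives a number 13 percentage points higher from compound 3 to compound 4 (beyond the scatter), which makes compound 4 the highest of the four. The two dichloro compounds now each have a single-change partner, and hydrogen in place of chloro gives a number 24 percentage points higher from compound 2 to compound 4 (beyond the scatter) and also a number 52 percentage points higher from compound 1 to compound 4 (beyond the scatter), so in both pairs the extra chloro goes with a lower number, and the loss is large only for compound 1. Nothing in the data accounts for any of these steps, so they stand as observations without a cause.

From the compounds shown here alone, whether fluoro, methyl, methoxy, an amine or a carboxylic acid on this aromatic carbon would hold the number of compound 4 or lose it remains open, as does what the aryl ring would give with hydrogen in place of the chloro of compound 4. Going by these compounds, each number is also the size of the inhibition at a single concentration, so how compound 4 ranks in potency remains open too.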